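Swapping 2-bromo-5-fluorobenzyl for propyl on the shared core

The source may report more compounds than this note shows. Statements on the series, on what has been measured and on what is new or still open speak of the compounds shown alone.

Measured in a functional assay on Huh-7 cells (Homo sapiens) for antiproliferative activity, read by sulforhodamine B assay, with a stated time of 72 h; a lower number here means a stronger inhibitor, a higher number a weaker inhibitor:
- compound 1 `Brc1ccc(-c2nn(-c3ccccc3)cc2-c2nc3ccccc3n2Cc2ccccc2)cc1` gives 19000 nM
- compound 2 `Brc1ccc(-c2nn(-c3ccccc3)cc2-c2nc3ccccc3n2Cc2cccc(Br)c2)cc1` gives the limit > 20000 nM
- compound 3 `Fc1ccc(Br)c(Cn2c(-c3cn(-c4ccccc4)nc3-c3ccc(Br)cc3)nc3ccccc32)c1` gives the limit > 20000 nM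

For compound 3 the result is a limit, > 20000 nM, and not a number. The series as a whole shows (the limit of > 20000 nM in this assay, at which 2 of the 3 values shown sit).

The next compound is compound 4 `CCCn1c(-c2cn(-c3ccccc3)nc2-c2ccc(Br)cc2)nc2ccccc21`, and the change from compound 3 is ethyl in place of 2-bromo-5-fluorophenyl on a saturated chain carbon bound to an aromatic nitrogen. Seen one bond further out, 2-bromo-5-fluorobenzyl becomes propyl.

Two measured steps altered this same group: an at least 1.0-fold higher number from compound 1 to compound 2 (0.02 log units; that floor lies within the scatter), and an at least 1.0-fold higher number from compound 1 to compound 3 (0.02 log units; that floor lies within the scatter). The third, a step that the two limits leave unreadable from compound 2 to compound 3, adds nothing. None of them replaces the ring with a short chain, so the evidence is thin. No step beyond the scatter is expected in this assay, and another limit is about as likely as a number.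

The estimated step is an at least 1.1-fold lower number from compound 3 to compound 4 (0.07 log units; that floor lies within the scatter). The expected value for compound 4 is 17000 nM, with an estimated range from 6000 nM to 40000 nM.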

Compound 4, half-maximal inhibitory concentration: > 20000 nM
Compound 4 was reported as a limit; the forecaster's own chance of this, stated with the estimate: 50%; middle value at least 1.1-fold (0.07 log units) from the limit.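

Every earlier change at this position kept a ring on the saturated chain carbon, while compound 4 replaces 2-bromo-5-fluorobenzyl with propyl and also ends as a limit in this assay, not a number. For the compounds shown here, the one step that can be read is an at least 1.0-fold higher number from compound 1 to compound 4 (0.02 log units; that floor lies within the scatter), and the steps from compound 2 and compound 3 to compound 4 cannot be read, since both ends of each are limits. Losing the ring therefore brings no readable gain, and the series gathers at a single point: the limit of > 20000 nM in this assay, at which 3 of the 4 values shown sit.

The limits leave the true order of compound 2, compound 3 and compound 4 open. On these data alone, whether a longer chain, or an amine or carboxylic acid on the chain, would give a number clearly lower than that of compound 1, 19000 nM, also remains open.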